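The compounds below may be only part of what the source reports. "The series", "measured", "known", "first", "only" and "open" are said of these compounds alone.

Measured compounds:
compound 1, `CCCCc1cc2ccccc2nc1-c1cc(-c2ccccc2)no1`: > 100000 nM
compound 2, `CCCc1cc2ccccc2nc1-c1cc(-c2ccc(F)cc2)no1`: 50300 nM

In a functional assay on COLO 205 cells (Homo sapiens) for inhibition, read by MTT assay, with a stated time of 24 h (on this read-out higher numbers stand for weaker inhibition and lower numbers for stronger inhibition), compound 1 gives > 100000 nM, which is a limit of the assay rather than a number (the limit of > 100000 nM in this assay, at which 1 of the 2 values shown sits). Going by the values given here, compound 2 gives 50300 nM in this assay and so holds the only true number among the two values. Compound 3 `CCCCc1cc2ccccc2nc1-c1cc(-c2ccc(F)cc2)no1` arises from compound 2 by methyl in place of hydrogen on a saturated chain carbon, three bonds along the chain from an aromatic carbon. Among the compounds with values here, no pair of measured compounds shows this single change, so its size is unknown. A small step toward weaker inhibition, or none beyond the scatter, is expected. Compound 3 is estimated at 70000 nM, between 30000 nM and 160000 nM, a step of a 1.4-fold higher number from compound 2 to compound 3 (0.14 log units; within the scatter).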

Compound 3, half-maximal inhibitory concentration: 25300 nM
For compound 3 the middle estimate is 2.8-fold (0.44 log units) above the measured one; measured number below the stated range.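

In this assay, going by these compounds alone, going from propyl to butyl gives a 2.0-fold lower number from compound 2 to compound 3 (0.30 log units; within the scatter), so the first measured change at this saturated chain carbon does not move the number beyond the scatter. Fluoro in place of hydrogen on an aromatic carbon, with the butyl chain kept, gives an at least 3.9-fold lower number from compound 1 to compound 3 (0.59 log units; beyond the scatter), the first step shown beyond the scatter. That step starts from a limit of the assay, held by compound 1: the limit of > 100000 nM in this assay, at which 1 of the 3 values shown sits.

The compounds shown leave open whether a longer chain such as pentyl, or an amine at the chain end, would shift the number beyond the scatter. They also leave open how chloro or methoxy would read in place of fluoro.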